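Swapping methoxy for methyl on an otherwise unchanged scaffold

A few compounds are considered here, and "the series" means these few. Any claim that something is new, unique, unknown or untested is made for them only; others in the source may bear on it.

Compound 3 `COc1ccc(-c2nc(CN3CCC(C(=O)c4ccc5c(c4)OCCO5)CC3)co2)cc1` is one of three close relatives measured in an ADME assay on HEK293 cells (Homo sapiens) for cytotoxicity, read by MTT assay, with a stated time of 36 h; a lower number here means a stronger inhibitor, a higher number a weaker inhibitor. Compound 3 reaches only a limit of the assay, > 150 ug/mL. Compound 1 `O=C(c1ccc2c(c1)OCCO2)C1CCN(Cc2coc(-c3ccccc3)n2)CC1` likewise gives a limit, > 150 ug/mL. Compound 2 `O=C(c1ccc2c(c1)OCCO2)C1CCN(Cc2coc(-c3ccc(F)c(F)c3)n2)CC1` also gives a limit, > 150 ug/mL. Because all three sit at the limit of > 150 ug/mL in this assay, at which 3 of the 3 values shown sit, none of the steps among them can be read: a step that the two limits leave unreadable from compound 1 to compound 2, a step that the two limits leave unreadable from compound 1 to compound 3 and a step that the two limits leave unreadable from compound 2 to compound 3. Compound 4 `Cc1ccc(-c2nc(CN3CCC(C(=O)c4ccc5c(c4)OCCO5)CC3)co2)cc1` differs from compound 3 by methyl in place of methoxy on an aromatic carbon. Within the data shown here, no measured step bears on this change, and nothing among the three relatives points to a readable shift, so in this assay no step beyond the scatter is expected, a number no higher from compound 3 to compound 4 (the limit leaves the size open). Compound 4 is therefore expected at 150 ug/mL, within 100 ug/mL to 300 ug/mL, most likely again reported as a limit.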

Compound 4, half-maximal inhibitory concentration: > 150 ug/mL
Compound 4: a limit, no number (the forecaster's own chance of this, stated with the estimate: 85%); the middle value lies on the limit itself.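

Compound 4 also gives only a limit, so its steps to compound 1, compound 2 and compound 3 in this assay cannot be read: the limit of > 150 ug/mL in this assay, at which 4 of the 4 values shown sit.

The compounds shown leave open at what concentration any of them would harm these cells, and whether swapping these groups changes that at all.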